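The source may report more compounds than this note shows. Statements on the series, on what has been measured and on what is new or still open speak of the compounds shown alone.

Measured so far:
- compound 1, `NNC(=O)CSc1nnc(-c2ccncc2)o1`: 3260 nM
- compound 2, `Cc1ccc(/C=N/NC(=O)CSc2nnc(-c3ccncc3)o2)cc1`: 21800 nM

Both compounds were tested in a functional assay on BGC-823 cells (Homo sapiens) for cytotoxicity, read by MTT assay, with a stated time of 48 h; a lower number here means a stronger inhibitor, a higher number a weaker inhibitor. Compound 2 has the higher of the two numbers: in this assay compound 2 gives 21800 nM, while compound 1 gives 3260 nM, a gap that lies beyond the usual scatter of this kind of measurement. Compound 2 thus stands as the weaker of the two.

Compound 3, `O=C(CSc1nnc(-c2ccncc2)o1)N/N=C/c1cc(Br)cc(Br)c1O`, keeps the shared core of compound 2 and differs only at the aromatic group on the carbon with a double bond to nitrogen: 3,5-dibromo-2-hydroxyphenyl in place of 4-methylphenyl on a carbon with a double bond to nitrogen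

Among the compounds with values here, no pair of measured compounds that differ in just this one place is available, so the size of the step cannot be taken from the data in hand. Within the data shown here, the only guidance is that the two measured compounds sit well apart and that compound 2 is the weaker one. The expected step from compound 2 to compound 3 is a 2.7-fold lower number from compound 2 to compound 3 (0.44 log units; beyond the scatter), a modest move toward a lower number, but with wide uncertainty. Compound 3 is therefore estimated at 8000 nM, with a range from 2000 nM to 30000 nM.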

Compound 3, half-maximal inhibitory concentration: 9610 nM
Estimate against measurement, compound 3: 1.2-fold (0.08 log units) below, and the stated range covers the measured number.
By their numbers in this assay, from the lowest: compound 1; then compound 3; then compound 2.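

In this assay, the aromatic group on the carbon with a double bond to nitrogen now has a measured effect: putting 3,5-dibromo-2-hydroxyphenyl in place of 4-methylphenyl gives a 2.3-fold lower number from compound 2 to compound 3 (0.36 log units; beyond the scatter), a modest step, but one beyond the usual scatter. Within the data shown here, this is the first direct reading at this place, and it shows that the number responds to what the aromatic ring carries, although the methyl group leaves while a hydroxyl group and two bromine atoms enter in the same change, so this single step cannot be divided among them. Nothing measured here explains why the number moves.

Still open, as far as these compounds go, is which part of the new group carries the step, a question that a ring bearing only the hydroxyl group or only the bromine atoms could answer. Also open, from the compounds shown here alone, is whether the number would move in the same direction with a different kind of group on the ring, such as an amine or a carboxylic acid.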